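Stability of an Acyloxymethyl Ester Variant of Compound 1

A few compounds are considered here, and "the series" means these few. Any claim that something is new, unique, unknown or untested is made for them only; others in the source may bear on it.

Compound 1 `CCOC(=O)C1=C(S[C@@H]2CN[C@H](C(=O)Nc3cccc(C(=O)O)c3)C2)[C@H](C)[C@@H]2[C@@H]([C@@H](C)O)C(=O)N12` reaches a limit rather than a number in an ADME assay for metabolic stability, read by LC-MS, with a stated time of 3 h, at pH 6.5, tested at 50 uM; on this read-out higher numbers stand for a more stable compound and lower numbers for a less stable compound: compound 1 gives > 95%. Compound 2 `CCOC(=O)OCOC(=O)C1=C(S[C@@H]2CN[C@H](C(=O)Nc3cccc(C(=O)OCOC(=O)OCC)c3)C2)[C@H](C)[C@@H]2[C@@H]([C@@H](C)O)C(=O)N12` likewise reaches a limit in this assay, where compound 2 gives > 95%. Within the data shown here, compound 1 thus stands at the limit of > 95% in this assay, at which 2 of the 2 values shown sit, and no measured step between compounds is available. Compound 3 `CCC(CC)C(=O)OCOC(=O)C1=C(S[C@@H]2CN[C@H](C(=O)Nc3cccc(C(=O)O)c3)C2)[C@H](C)[C@@H]2[C@@H]([C@@H](C)O)C(=O)N12` differs from compound 1 by ((pentan-3-yl)carbonyl)oxy in place of methyl on a saturated chain carbon bound to an oxygen next to a carbonyl group. Among the measured compounds shown here, with no measured step to lean on, the step of a number no higher from compound 1 to compound 3 (the limit leaves the size open) is expected to stay within the usual scatter, in no particular direction. Compound 3 is estimated at 95%, between 85% and 99%.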

Compound 3, percent of the compound remaining: > 95%
Compound 3: no number, only a limit (the forecaster's own chance of this, stated with the estimate: 65%); the middle value sits exactly at the limit.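

No step can be read from compound 1 to compound 3 in this assay, because both results are limits: the limit of > 95% in this assay, at which 3 of the 3 values shown sit.

The compounds shown leave open whether compound 1, compound 2 and compound 3 differ at all in this assay.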